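Methyl in place of phenylsulfonyl on an aromatic nitrogen

The source may report more compounds than this note shows. Statements on the series, on what has been measured and on what is new or still open speak of the compounds shown alone.

In a functional assay on HT-29 cells (Homo sapiens) for inhibition (a lower number here means a stronger inhibitor, a higher number a weaker inhibitor), compound 2 (`O=S(=O)(c1ccccc1)n1ccc2cc(/C=C/c3ccc4ccccc4c3)ccc21`) gives > 5000 nM which is a limit and not a number. Compound 3 (`O=S(=O)(c1ccccc1)n1ccc2cc(/C=C\c3ccc4ccccc4c3)ccc21`) gives > 5000 nM and that too is only a limit. Among the measured compounds shown here, compound 1 (`COc1cc2ccc(CCc3ccc4ccccc4c3)cc2cc1O`) gives a true reading of 3590 nM in this assay as the sole number available. Compound 4 (`Cn1ccc2cc(/C=C/c3ccc4ccccc4c3)ccc21`) departs from compound 2 through methyl in place of phenylsulfonyl on an aromatic nitrogen with methyl in place of phenylsulfonyl on an aromatic nitrogen. For the measured compounds named here, the one measured step (a step that the two limits leave unreadable from compound 2 to compound 3) concerns only configuration (the fact that compounds 2 and 3 differ only in the configuration as drawn) and does not touch that nitrogen, so it offers no size to carry over. With compound 2 at a limit, a readable result could lie only on the stronger side. Compound 1 (3590 nM) suggests a modest gain at best. The expected at least 1.4-fold lower number from compound 2 to compound 4 (0.15 log units; that floor lies within the scatter) is therefore small and uncertain in this assay for now. Compound 4 is estimated at 3500 nM with an expected range from 800 nM to 10000 nM in this measurement.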

Compound 4, half-maximal inhibitory concentration: > 5000 nM
Compound 4 was reported as a limit; the forecaster's own chance of this, stated with the estimate: 45%; middle value at least 1.4-fold (0.15 log units) from the limit.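

In this assay compound 4 gives > 5000 nM, which is a limit; compound 2 also stands at a limit, and the step between these two compounds cannot be read. As far as these compounds go, how large any effect of methyl in place of phenylsulfonyl on an aromatic nitrogen might be remains open.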